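Replacing the 4-chloropiperidin-1-yl group of compound 2

The source may report more compounds than this note shows. Statements on the series, on what has been measured and on what is new or still open speak of the compounds shown alone.

Compound 1 `CCc1nc2cc(Cl)ccn2c1C(=O)NCc1ccc(-c2ccc(Cl)cc2)cc1`: > 1 h (a limit)
Compound 2 `CCc1nc2cc(Cl)ccn2c1C(=O)NCc1ccc(N2CCC(Cl)CC2)cc1`: 0.0867 h

For the measured compounds named here, in an ADME assay (liver, Mus musculus) for metabolic stability, using microsomes (a lower number here means that the compound disappears faster, a higher number that the compound lasts longer), compound 2 gives 0.0867 h, the only actual number so far. Compound 1 shows > 1 h, which is a limit of the assay and not a number.

Compound 3 `CCc1nc2cc(Cl)ccn2c1C(=O)NCc1ccc(N2CC3CCCCC3C2)cc1` is the next to be read, and it changes compound 2 at a single place: a group of 9 heavy atoms (8 carbon, 1 nitrogen; one five-membered non-aromatic ring with 1 hetero atom, one six-membered non-aromatic ring of carbon only) in place of a group of 7 heavy atoms (5 carbon, 1 nitrogen, 1 chlorine; one six-membered non-aromatic ring with 1 hetero atom), on an aromatic carbon. Going by the values given here, the one measured step that bears on this place is an at least 11-fold lower number from compound 1 to compound 2 (1.06 log units; beyond the scatter). That step is large and beyond the scatter, and it exchanges 4-chlorophenyl for 4-chloropiperidin-1-yl. Among the compounds with values here, it gives only indirect guidance, since no measured step exchanges one non-aromatic ring group for another. Compound 3 keeps a non-aromatic ring group on that aromatic carbon, as does compound 2 at 0.0867 h, so no large recovery is expected. The expected outcome is a 1.1-fold lower number from compound 2 to compound 3 (0.03 log units; within the scatter), which would lie within the scatter. For compound 3 the estimated half-life is 0.08 h, with an expected range from 0.03 h to 0.25 h.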

Compound 3, half-life: 0.105 h
The estimate for compound 3 lay 1.3-fold (0.12 log units) below the measured number; measured number inside the range.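

In this assay, for the compounds shown here, the first exchange between two non-aromatic ring groups at this position gives a 1.2-fold higher number from compound 2 to compound 3 (0.08 log units; within the scatter), so dropping the chlorine of 4-chloropiperidin-1-yl and adding a second non-aromatic ring leaves the read-out where it was. The comparison with the aromatic group gives an at least 9.5-fold lower number from compound 1 to compound 3 (0.97 log units; beyond the scatter), so the gap first seen with compound 2 appears again with a second, different non-aromatic ring group, and in these three compounds it separates 4-chlorophenyl from both non-aromatic ring groups. Compound 1 gives a limit and not a number, so the full size of that gap stays unknown: the limit of > 1 h in this assay, at which 1 of the 3 values shown sits.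

The compounds shown do not tell whether the gap follows the aromatic ring itself or the attachment through a ring nitrogen, a question that a cyclohexyl group joined through carbon, or an unsubstituted phenyl or pyridine ring, would bear on. They also leave open whether a non-aromatic ring group with a second hetero atom, such as morpholine or a piperazine, would stay with compound 2 and compound 3 or move toward compound 1.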